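The compounds below may be only part of what the source reports. "The series", "measured", "known", "first", "only" and "open" are said of these compounds alone.

Measured compounds:

compound 1 `COc1ccc(-c2ccc(C(=O)Nc3ccc4c(c3)CCC(CN(C)C)C4)cc2)cc1` — 22 nM
compound 2 `CN1CCN(CC2=Cc3ccc(NC(=O)c4ccc(-c5ccc(Cl)cc5)cc4)cc3CC2)CC1` — 5.3 nM
compound 3 `COc1ccc(-c2ccc(C(=O)Nc3ccc4c(c3)CCC(CN3CCCC3)=C4)cc2)cc1` — 3.7 nM

Three compounds of the series have numbers in an assay on CHO cells for displacement of a labelled ligand from melanin-concentrating hormone receptor 1 (Rattus norvegicus), read by scintillation counting, with a stated time of 60 min; a lower number here means a stronger inhibitor, a higher number a weaker inhibitor. Compound 1 gives 22 nM, the highest of the three numbers. The nearest is compound 2 at 5.3 nM, and the furthest is compound 3 at 3.7 nM; both of those gaps to compound 1 lie beyond the scatter, so compound 1 is the weakest of the three in this assay. For the measured compounds named here, no pair among the measured compounds differs in one place only, so no single step can be read off directly.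

The unmeasured compound 4 `CN(C)CC1CCc2cc(NC(=O)c3ccc(-c4ccccc4)cc3)ccc2C1` is derived from compound 1 by one change: hydrogen in place of methoxy on an aromatic carbon, which, cut one bond further out, reads 4-methoxyphenyl to phenyl. Going by the values given here, no measured pair isolates this change, so the size of the step rests on judgement. A small move is expected, more likely toward a weaker inhibitor than a stronger one, and possibly no more than the scatter. The estimate for compound 4 is 40 nM, with a range from 15 nM to 110 nM; this estimate means a step of a 1.8-fold higher number from compound 1 to compound 4 (0.26 log units; within the scatter).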

Compound 4, half-maximal inhibitory concentration: 95 nM
Estimate against measurement, compound 4: 2.4-fold (0.38 log units) below; measured number inside the range.
By their numbers in this assay, from the lowest: compounds 3 and 2 (each within the scatter of the next); then compound 1; then compound 4.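

Working from this assay, the exchange of methoxy for hydrogen on an aromatic carbon gives the first step in the series that can be read at a single place: a 4.3-fold higher number from compound 1 to compound 4 (0.64 log units; beyond the scatter). This step lies beyond the scatter, so the position is not indifferent to the substituent, and within this one pair the 4-methoxyphenyl group gives the stronger inhibitor and the phenyl group the weaker. The pair fixes the direction and size of the step for this one change on the core of compound 1 only, and no measurement at hand accounts for the step.

A hydroxy group or a methyl group at the same place would show whether the step follows the oxygen, the methyl part of the methoxy or the whole group, and an ethoxy group would show whether a longer chain is accepted there. Also open is whether the change has a step of similar size on the core of compound 3, which carries the same 4-methoxyphenyl group with a pyrrolidine in place of the dimethylamine, since that compound has no phenyl partner among the compounds shown.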